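This account rests on a few compounds, and the source may have more. Where it says the series, first, only, none or still open, it means among the compounds named here.

Measured in an ADME assay on HepG2 cells (Homo sapiens) for cytotoxicity, read by luminescence, with a stated time of 72 h; on this read-out higher numbers stand for an effect only at larger amounts of compound and lower numbers for an effect already at smaller amounts:
- Compound 1 `CCOC(=O)c1c(-c2cccc(OC(C)C)c2)[nH]c2cc(OC)ccc2c1=O` gives > 21500 nM as a limit
- Compound 2 `CCOC(=O)c1c(-c2cccc(Cl)c2)[nH]c2cc(OC)ccc2c1=O` gives > 21500 nM as a limit
- Compound 3 `CCOC(=O)c1c(-c2cccc(Br)c2)[nH]c2cc(OC)ccc2c1=O` gives > 21500 nM as a limit

Compound 3 has no number and stands only at the assay limit, as the whole series does: the limit of > 21500 nM in this assay, at which 3 of the 3 values shown sit, is all that is shown. Compound 4 `CCOC(=O)c1c(-c2cccc(NC(C)=O)c2)[nH]c2cc(OC)ccc2c1=O` carries acetamido in place of bromo on an aromatic carbon, meta to a large group, the difference being acetamido in place of bromo on an aromatic carbon in full. Going by the values given here, the steps that bear on it are a step that the two limits leave unreadable from compound 1 to compound 3 and a step that the two limits leave unreadable from compound 2 to compound 3 as well as a step that the two limits leave unreadable from compound 1 to compound 2, so none offers a size. In this assay the expected outcome is therefore no step beyond the scatter, with no direction favoured, and the estimated step is a step that the limit leaves unreadable from compound 3 to compound 4 on that basis. Compound 4 is estimated at 25000 nM, with an expected range from 12000 nM to 50000 nM overall.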

Compound 4, half-maximal effective concentration: > 21500 nM
Compound 4: a limit, no number (the forecaster's own chance of this, stated with the estimate: 85%); the middle value does not contradict the limit.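

No step can be read between compound 4 and compound 1, compound 2 or compound 3 in this assay, since all four stand only as limits: the limit of > 21500 nM in this assay, at which 4 of the 4 values shown sit.

The compounds shown leave open at what concentration any of the four would show an effect.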